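A few compounds are considered here, and "the series" means these few. Any claim that something is new, unique, unknown or untested is made for them only; others in the source may bear on it.

Working notes on the series, read in an ADME assay on the whole organism (plasma, Rattus norvegicus) for pharmacokinetics, read by LC-MS, at a dose of 0.1 mg/kg by the intravenous route; a lower number here means that more of the compound stays in the plasma, a higher number that more of the compound sits outside the plasma. Compound 1 `Cc1cnc(Oc2cc(Cl)c(F)c(-c3ccc4c(c3)CC[C@H](CCC(=O)O)O4)c2)s1` gives 0.14 L/kg. Compound 3 `O=C(O)CC[C@H]1CCc2cc(-c3nc(OC4CCC4)ccc3F)ccc2O1` gives 0.23 L/kg, which lies within the scatter of compound 1. Compound 2 `COc1cc(O[C@H]2C[C@H](OC)C2)nc(-c2ccc3c(c2)CC[C@H](CCC(=O)O)O3)c1F` gives 0.49 L/kg, a higher number than compound 1 and beyond the scatter. Compound 1 therefore stands at the low end of the range, level with compound 3.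

The next compound is compound 4 `COc1cc(Oc2ncc(C)s2)cc(-c2ccc3c(c2)CC[C@H](CCC(=O)O)O3)c1F`, which keeps the (5-methyl-1,3-thiazol-2-yl)oxy group of compound 1 and changes in one place: methoxy in place of chloro on an aromatic carbon. Methoxy takes the place of chloro on an aromatic carbon, ortho to a fluoro group. Among the compounds with values here, no measured pair differs in one place only, so no direct size exists for this change. Within the data shown here, compound 2 also carries a methoxy group and gives 0.49 L/kg, but no single step links it to compound 1, so that value offers only a weak lean upward. The expected move in this assay is small, upward if anything, and not beyond the scatter. The estimated move is a 1.4-fold higher number from compound 1 to compound 4 (0.13 log units; within the scatter). The value expected for compound 4 is 0.19 L/kg, with an estimated range from 0.1 L/kg to 0.36 L/kg.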

Compound 4, volume of distribution at steady state: 0.15 L/kg
Compound 4: the middle estimate sits 1.3-fold (0.10 log units) above what was measured; low and high end bracket the measured number.
By their numbers in this assay, from the lowest: compounds 1, 4 and 3 (each within the scatter of the next); then compound 2.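

Methoxy in place of chloro, on an aromatic carbon ortho to a fluoro group, now has a direct size in this assay as the first single-place pair of the series: a 1.1-fold higher number from compound 1 to compound 4 (0.03 log units; within the scatter) with the (5-methyl-1,3-thiazol-2-yl)oxy group held fixed. At this position, in the setting of compound 1, the exchange adds a heavy atom and a hydrogen-bond acceptor without moving the volume of distribution beyond the scatter, so chloro and methoxy cannot be told apart here. No supporting measurement accompanies this result, so the flat step stands as an observation without an explanation.

Still open, on these data alone, is whether this position tolerates other kinds of group in the same way, such as an amine, a nitrile or a longer alkoxy chain. Within the data shown here, also open is whether the same exchange stays as small when the (5-methyl-1,3-thiazol-2-yl)oxy group gives way to another substituent, since only this one pair carries the change.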